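Benzothiazole thioacetamide series: cytotoxicity notes, methoxy for chloro

This account rests on a few compounds, and the source may have more. Where it says the series, first, only, none or still open, it means among the compounds named here.

Measured so far:
compound 1 `O=C(CSc1nc2ccc(NC(=O)c3ccc(Cl)cc3)cc2s1)NCc1ccc(Cl)cc1`: 17800 nM
compound 2 `O=C(CSc1nc2ccc(NC(=O)c3ccccc3)cc2s1)NCc1ccc(Cl)cc1`: 30100 nM

In a functional assay on HepG2 cells (Homo sapiens) for cytotoxicity, read by MTT assay, with a stated time of 48 h (on this read-out lower numbers stand for stronger inhibition and higher numbers for weaker inhibition), compound 1 gives 17800 nM and compound 2 gives 30100 nM. Within the data shown here, the single measured step, a 1.7-fold higher number from compound 1 to compound 2 (0.23 log units; within the scatter), comes from hydrogen in place of chloro on an aromatic carbon of the benzamide part and stays within the scatter. Among the measured compounds shown here, compound 2 therefore holds the highest of the two numbers, with compound 1 as its only neighbour and not separated from it beyond the scatter.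

Compound 3 `COc1ccc(CNC(=O)CSc2nc3ccc(NC(=O)c4ccccc4)cc3s2)cc1` is not yet measured. It differs from compound 2 by methoxy in place of chloro on an aromatic carbon of the benzylamide part. For the measured compounds named here, no measured step touches this ring or this exchange; the only step available concerns the other aromatic ring and was itself within the scatter. Nothing in the two numbers argues for a change beyond the scatter in either direction, so the expected step of a 1.0-fold lower number from compound 2 to compound 3 (0.00 log units; within the scatter) is small. Compound 3 is accordingly estimated at 30000 nM, with a range from 12000 nM to 75000 nM in this assay.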

Compound 3, half-maximal inhibitory concentration: 12700 nM
Beside the measured number, compound 3's estimate is 2.4-fold (0.37 log units) above it, within the range that was stated.
By their numbers in this assay, from the lowest: compounds 3, 1 and 2 (each within the scatter of the next, the first and the last beyond it).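

In this assay, among these compounds, the exchange of 4-chlorobenzyl for 4-methoxybenzyl gives a 2.4-fold lower number from compound 2 to compound 3 (0.37 log units; beyond the scatter) and is the first step in these compounds to lie beyond the scatter, though its size is modest. Among the compounds shown here, the one earlier step, a 1.7-fold higher number from compound 1 to compound 2 (0.23 log units; within the scatter) and made on the benzamide part, stayed within the scatter, so the position para to a large group on the benzylamide part is the first place here where a substituent exchange separates two compounds. The available data offer nothing that accounts for this step.

A single exchange at this position leaves open whether the number follows the oxygen of methoxy or the group as a whole, and a hydroxy, ethyl or dimethylamino group at the same place would help to separate these readings. On these data alone, it is also open whether methoxy in place of chloro on the benzamide part would give a step of similar direction and size, or whether the change seen here is confined to the benzylamide part.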